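Amide group swap from compound 3 to compound 4

The compounds below may be only part of what the source reports. "The series", "measured", "known", "first", "only" and "open" are said of these compounds alone.

In an ADME assay on MT4 cells (Homo sapiens) for cytotoxicity, read by MTT assay (on this read-out lower numbers stand for higher toxicity in this test and higher numbers for lower toxicity in this test), compound 3 (`Cc1cc(C)cc(S(=O)(=O)c2c(C(=O)NC(c3ccc(Cl)cc3)C3CC3)[nH]c3ccc(Cl)cc23)c1`) gives > 47300 nM as a limit, not a number. Compound 1 (`Cc1cc(C)cc(S(=O)(=O)c2c(C(=O)NCc3cccc(F)c3F)[nH]c3ccc(Cl)cc23)c1`) gives > 51100 nM as a limit too. Going by the values given here, compound 2 (`Cc1cc(C)cc(S(=O)(=O)c2c(C(=O)NC(C)C(=O)NC(C)c3ccccc3)[nH]c3ccc(Cl)cc23)c1`) gives 21700 nM as the only true number so far. Compound 4 (`Cc1cc(C)cc(S(=O)(=O)c2c(C(=O)NC(C)c3ccco3)[nH]c3ccc(Cl)cc23)c1`) differs from compound 3 by a group of 7 heavy atoms (6 carbon, 1 oxygen; one five-membered aromatic ring with 1 hetero atom) in place of a group of 11 heavy atoms (10 carbon, 1 chlorine; one three-membered non-aromatic ring of carbon only, one six-membered aromatic ring of carbon only), on an amide-type nitrogen on the same nitrogen. Among the compounds with values here, the only measured step bearing on this change is a step that the two limits leave unreadable from compound 1 to compound 3 and no size can be carried over from it. With compound 2 at 21700 nM as the sole anchor, a modest fall or no readable change is expected. The estimated size is an at least 1.3-fold lower number from compound 3 to compound 4 (0.13 log units; that floor lies within the scatter) on thin evidence. For compound 4 the estimate is 35000 nM with an expected range from 15000 nM to 60000 nM in this assay as read here.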

Compound 4, half-maximal cytotoxic concentration: > 54700 nM
Compound 4 was reported as a limit; the forecaster's own chance of this, stated with the estimate: 55%; middle value at least 1.5-fold (0.19 log units) away from the limit.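

In this assay, going by these compounds alone, the first readable step at this amide-type nitrogen is an at least 2.5-fold higher number from compound 2 to compound 4 (0.40 log units; beyond the scatter), with furan-2-yl in place of (1-phenylethyl)carbamoyl on the saturated chain carbon. The number of compound 2 is thus not kept once that carbamoyl group leaves for the furan ring. The steps from compound 3 and from compound 1 to compound 4 cannot be read, all three values being limits. Open, from the compounds shown here alone, is how far compound 1, compound 3 and compound 4 lie apart, and whether an amine or a carboxylic acid on that chain carbon would give a true number in this assay.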